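Cyano at the pendant phenyl of compound 2

This account rests on a few compounds, and the source may have more. Where it says the series, first, only, none or still open, it means among the compounds named here.

In a functional assay on CHO-K1 cells for antagonist activity at adenosine receptor A1 (Homo sapiens), read by a beta-galactosidase reporter and cAMP accumulation, with stated times of 15 min and 6 h (on this read-out lower numbers stand for stronger inhibition and higher numbers for weaker inhibition), compound 2 `Nc1nc(-c2ccccc2)nc2sc(Cc3ccccc3)cc12` gives 151 nM, the lower of the two numbers in hand, while compound 1 `Cc1ccc(-c2nc(N)c3cc(Cc4ccccc4)sc3n2)o1` gives 298 nM; the step of a 2.0-fold lower number from compound 1 to compound 2 (0.30 log units; within the scatter) lies within the scatter. Compound 3 `N#Cc1cccc(-c2nc(N)c3cc(Cc4ccccc4)sc3n2)c1` carries cyano in place of hydrogen on an aromatic carbon. Among the compounds with values here, no measured step adds a substituent to the phenyl; the only change so far, phenyl for 5-methylfuran-2-yl, swaps the group on the shared core and stayed within the scatter. The step of a 1.0-fold lower number from compound 2 to compound 3 (0.00 log units; within the scatter) is therefore expected to stay within the scatter, in no settled direction. Compound 3 is estimated at 150 nM, with a range from 50 nM to 500 nM.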

Compound 3, inhibition constant: 222 nM
For compound 3 the middle estimate is 1.5-fold (0.17 log units) below the measured one; measured number inside the range.
By their numbers in this assay, from the lowest: compounds 2, 3 and 1 (each within the scatter of the next).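

In this assay, within the data shown here, a substituent on the phenyl of compound 2 is seen for the first time: cyano, meta to a large group, stays within the scatter (a 1.5-fold higher number from compound 2 to compound 3 (0.17 log units; within the scatter)). Against the 5-methylfuran-2-yl group, 3-cyanophenyl also stays within the scatter (a 1.3-fold lower number from compound 1 to compound 3 (0.13 log units; within the scatter)), so none of the three groups on the shared core separates from the others. No data are available to explain these results. As far as these compounds go, whether an amine, a carboxylic acid or a methoxy group on this ring would move the number beyond the scatter remains open. Cyano at other places on the ring also remains open.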